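Swapping the ester piperidine for an ethylpiperidine

A few compounds are considered here, and "the series" means these few. Any claim that something is new, unique, unknown or untested is made for them only; others in the source may bear on it.

Going by the values given here, compound 2 `CCOC(=O)C1CCN(C(=O)CN2CN(c3ccccc3)C3(CCN(C(=O)c4ccc(C(C)(C)C)cc4)CC3)C2=O)CC1` gives 3100 nM in an assay on HEK293 cells for displacement of a labelled ligand from NPC1-like intracellular cholesterol transporter 1 (Homo sapiens) (a lower number here means a stronger inhibitor, a higher number a weaker inhibitor), the lowest of the two numbers measured so far. Among the compounds with values here, compound 1 `CC(C)(C)c1ccc(C(=O)N2CCC3(CC2)C(=O)N(CC(=O)N2CCN(S(C)(=O)=O)CC2)CN3c2ccccc2)cc1` gives 19000 nM in this assay, and the single known step, a 6.1-fold lower number from compound 1 to compound 2 (0.79 log units; beyond the scatter), came from one amide-linked ring exchanged for another. Compound 3 `CCC1CCCN(C(=O)CN2CN(c3ccccc3)C3(CCN(C(=O)c4ccc(C(C)(C)C)cc4)CC3)C2=O)C1` changes the same place again: 3-ethylpiperidin-1-yl in place of 4-(ethoxycarbonyl)piperidin-1-yl on a carbonyl carbon. Within the data shown here, only that one step bears on it, and it concerns a different pair of groups, so the direction is uncertain. The expected step is a 1.5-fold higher number from compound 2 to compound 3 (0.16 log units; within the scatter), small and toward a higher number. Compound 3 is estimated at 4500 nM, within 1200 nM to 16000 nM.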

Compound 3, half-maximal inhibitory concentration: 3900 nM
Compound 3: the middle estimate sits 1.2-fold (0.06 log units) above what was measured; the measured number falls inside the stated range.
By their numbers in this assay, from the lowest: compounds 2 and 3 (each within the scatter of the next); then compound 1.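

In this assay, a 1.3-fold higher number from compound 2 to compound 3 (0.10 log units; within the scatter) shows that this place on the carbonyl carbon accepts 3-ethylpiperidin-1-yl, with 0 hydrogen-bond acceptors, as well as it accepts the ester-bearing piperidine. With a 4.9-fold lower number from compound 1 to compound 3 (0.69 log units; beyond the scatter), two differently substituted piperidines now both stand apart from 4-(methylsulfonyl)piperazin-1-yl. No measurement here explains this.

The compounds shown leave open whether a plain piperidin-1-yl would read the same. They also leave open how a piperidine carrying a carboxylic acid or an amine would behave.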